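Paw edema inhibition: hydroxyphenyl in place of chlorophenyl

The compounds below may be only part of what the source reports. "The series", "measured", "known", "first", "only" and "open" are said of these compounds alone.

Compound 1 `NS(=O)(=O)c1ccc(N2N=C(c3cccc(O)c3)C[C@H]2c2ccc(Cl)cc2)cc1` has the lowest number of the three measured compounds in a functional assay on the whole organism (strain Wistar albino) for inhibition, with Rattus norvegicus as the target, read by paw edema, with stated times of 30 min and 5 h, at a dose of 0.05 mmol/kg (a higher number here means more inhibition at the dose given (going by the name of the read-out), a lower number less inhibition), where compound 1 gives 51.8%. Its nearest neighbour is compound 2 `COc1ccc([C@@H]2CC(c3cccc(O)c3)=NN2c2ccc(S(N)(=O)=O)cc2)cc1`, which in this assay gives 62.9%, and the furthest is compound 3 `NS(=O)(=O)c1ccc(N2N=C(c3cccc(O)c3)C[C@H]2c2ccc(O)cc2)cc1`, which in this assay gives 77.7%. The two measured steps out of compound 1 both raise inhibition: a number 11.1 percentage points higher from compound 1 to compound 2 (beyond the scatter), and a number 25.9 percentage points higher from compound 1 to compound 3 (beyond the scatter). The step of a number 14.8 percentage points higher from compound 2 to compound 3 (beyond the scatter) shows that the free hydroxy group adds further to the methoxy.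

Compound 4 `NS(=O)(=O)c1ccc(N2N=C(c3cccc(O)c3)C[C@H]2c2ccccc2O)cc1` is not yet measured in this assay. It differs from compound 1 as follows: 2-hydroxyphenyl in place of 4-chlorophenyl on a saturated ring carbon. Among the measured compounds shown here, the closest guide is the step from compound 1 to compound 3, which also exchanged chloro for hydroxy on an aromatic carbon, but the entering group in compound 4 is 2-hydroxyphenyl, a group on which no measured step exists, so the size of the effect is less certain.

The author therefore expects an increase in this assay for compound 4, estimated as a number 16.2 percentage points higher from compound 1 to compound 4 (beyond the scatter). Compound 4 is expected to give about 68%, with a likely range from 52% to 82%.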

Compound 4, a percentage reported as inhibition, in the whole organism at one dose (the size of the read-out at that dose, not a potency): 55.5%
Estimate against measurement, compound 4: 12.5 percentage points above; the range from low to high includes it.
By their numbers in this assay, from the lowest: compounds 1, 4 and 2 (each within the scatter of the next, the first and the last beyond it); then compound 3.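

In this assay, moving from 4-hydroxyphenyl to 2-hydroxyphenyl on the saturated ring carbon gives a number 22.2 percentage points lower from compound 3 to compound 4 (beyond the scatter), although the two groups have the same heavy atoms, so a hydroxy group on this phenyl ring does not by itself bring the high number of the 4-hydroxyphenyl compound. The other two exchanges at this carbon give a number 3.7 percentage points higher from compound 1 to compound 4 (within the scatter) and a number 7.4 percentage points lower from compound 2 to compound 4 (within the scatter), so 2-hydroxyphenyl cannot be told apart in this read-out from either 4-chlorophenyl or 4-methoxyphenyl. Nothing at hand bears on why the place of the hydroxy group on this ring matters here.

On these data alone, it remains open how an amine or a carboxylic acid on this phenyl ring, in place of the hydroxy group, would read in this assay. As far as these compounds go, since each number is the size of the inhibition at a single dose and not a potency, it is also open whether the gap between the two hydroxyphenyl compounds would persist at other doses.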